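From 3-ethoxyphenyl to 4-hydroxyphenyl on the shared core

The compounds below may be only part of what the source reports. "The series", "measured", "known", "first", "only" and "open" are said of these compounds alone.

- Compound 1 `COC(=O)N1N=C(c2ccccc2)CC1c1cc(OC)c(OC)c(OC)c1`: 3950 nM
- Compound 2 `CCCOC(=O)N1N=C(c2cccc(O)c2)CC1c1cc(OC)c(OC)c(OC)c1`: > 10000 nM (a limit of the assay)
- Compound 3 `CCOc1cccc(C2=NN(C(=O)OC)C(c3cc(OC)c(OC)c(OC)c3)C2)c1`: 8360 nM

These three compounds were tested in a functional assay on HepG2 cells (Homo sapiens) for antiproliferative activity, read by MTT assay, with a stated time of 48 h; on this read-out lower numbers stand for stronger inhibition of growth and higher numbers for weaker inhibition of growth. Within the data shown here, only two of them gave numbers, and compound 3 has the higher one, at 8360 nM. Its nearest neighbour is compound 1, at 3950 nM. The result for compound 2, > 10000 nM, is a limit and not a number. Among the measured compounds shown here, no single-place step links compound 2 to the others, so it gives no step size.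

The next compound is compound 4 `COC(=O)N1N=C(c2ccc(O)cc2)CC1c1cc(OC)c(OC)c(OC)c1`, with 4-hydroxyphenyl in place of 3-ethoxyphenyl on a carbon with a double bond to nitrogen. For the measured compounds named here, one measured step bears on this change: a 2.1-fold higher number from compound 1 to compound 3 (0.33 log units; beyond the scatter), where ethoxy replaced hydrogen on an aromatic carbon. Going by the values given here, compound 4 no longer carries that ethoxy, but the effect of its hydroxyl has no clean measured step. A modest move towards a lower number in this assay is therefore expected, possibly no larger than the scatter. The expected change is a 1.9-fold lower number from compound 3 to compound 4 (0.27 log units; within the scatter). For compound 4 the estimated value is 4500 nM, with an expected range from 1500 nM to 10000 nM.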

Compound 4, concentration for 50% growth inhibition: 7820 nM
For compound 4 the middle estimate is 1.7-fold (0.24 log units) below the measured one; low and high end bracket the measured number.
By their numbers in this assay, from the lowest: compounds 1, 4 and 3 (each within the scatter of the next, the first and the last beyond it). At a limit, above all of these: compound 2.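

In this assay, among these compounds, 4-hydroxyphenyl in place of 3-ethoxyphenyl on the carbon with a double bond to nitrogen gives a 1.1-fold lower number from compound 3 to compound 4 (0.03 log units; within the scatter), so this exchange, which no earlier pair could test, does not separate the two substituted rings. The hydroxy step gives a 2.0-fold higher number from compound 1 to compound 4 (0.30 log units; within the scatter), which stays within the scatter, whereas the ethoxy step gave a 2.1-fold higher number from compound 1 to compound 3 (0.33 log units; beyond the scatter), beyond it, so neither compound 3 nor compound 4 is set apart from the other, and only compound 3 is set apart from compound 1. Nothing measured here accounts for these steps.

Among the compounds shown here, compound 2 remains a limit of the assay, > 10000 nM, and no single-place step links it to the other compounds, so the hydroxy group it carries on its phenyl ring cannot be read apart from its different ester. On these data alone, it also stays open whether an amine or a carboxylic acid on this phenyl ring, or a longer chain in place of the ethoxy, would give a step beyond the scatter.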